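This account rests on a few compounds, and the source may have more. Where it says the series, first, only, none or still open, it means among the compounds named here.

For the measured compounds named here, compound 1 (`CCOc1cc([C@](O)(CCN(C)C)[C@@H](c2cc3cc(Br)ccc3nc2OC)c2cccc(OC)c2F)cc(OC)n1`) gives 4000 ng.h/mL in an ADME assay on the whole organism (Mus musculus, strain CD-1) for pharmacokinetics, at a dose of 10 mg/kg by the oral route (a higher number here means more compound in the circulation at the dose given, a lower number less compound in the circulation), while compound 2 (`COc1cc([C@](O)(CCN(C)C)[C@@H](c2cc3cc(Br)ccc3nc2OC)c2cccc(OC)c2F)cc(OC(F)F)n1`) gives 14400 ng.h/mL there, the higher of the two numbers so far. These two compounds differ by difluoromethyl in place of ethyl on an oxygen on an aromatic ring. Going by the values given here, that single change gives a 3.6-fold higher number from compound 1 to compound 2 (0.56 log units; beyond the scatter) and is the only measured step available.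

Compound 3 (`COc1cccc([C@H](c2cc3cc(Br)ccc3nc2OC)[C@@](O)(CCN(C)C)c2cc(SC)nc(SC)c2)c1F`) has not been measured yet, and it differs from compound 2 by a group of 10 heavy atoms (7 carbon, 1 nitrogen, 2 sulfur; one six-membered aromatic ring with 1 hetero atom) in place of a group of 12 heavy atoms (7 carbon, 1 nitrogen, 2 oxygen, 2 fluorine; one six-membered aromatic ring with 1 hetero atom), on a saturated chain carbon bound to an oxygen on a saturated carbon and two saturated chain carbons in a larger change than the measured one. Among the compounds with values here, no measured compound carries sulfur, so the measured step is only a loose guide. Compound 3 loses the difluoromethyl group found in compound 2, so a fall towards compound 1 at 4000 ng.h/mL is expected rather than a further rise. The estimated change is a 2.9-fold lower number from compound 2 to compound 3 (0.46 log units; beyond the scatter) with wide uncertainty on its size. The estimate for compound 3 is 5000 ng.h/mL with an expected range from 1500 ng.h/mL to 15000 ng.h/mL in this assay once it is measured.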

Compound 3, area under the concentration-time curve: 8400 ng.h/mL
Compound 3: middle estimate off by 1.7-fold (0.23 log units), on the low side, within the range that was stated.
By their numbers in this assay, from the lowest: compound 1; then compounds 3 and 2 (each within the scatter of the next).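

In this assay, the group of 10 heavy atoms with 2 sulfur holds up about as well as the group carrying difluoromethyl, with a 1.7-fold lower number from compound 2 to compound 3 (0.23 log units; within the scatter), so these two compounds cannot be told apart in this measurement. The same sulfur-bearing group still stands clear of the group carrying ethyl in compound 1, with a 2.1-fold higher number from compound 1 to compound 3 (0.32 log units; beyond the scatter), although this step is modest. Difluoromethyl is therefore not the only group among these compounds that lifts the number beyond that of compound 1 at this position, and the data give no explanation for this result.

As far as these compounds go, the step from compound 2 to compound 3 removes oxygen and fluorine and brings in sulfur in a single change, so the contribution of each atom type remains unknown. From the compounds shown here alone, it also remains open how this position would respond to a ring group carrying an amine, a chlorine or a nitrile, and whether such groups would stand with compound 2 and compound 3 or nearer to compound 1.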